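The source may report more compounds than this note shows. Statements on the series, on what has been measured and on what is new or still open speak of the compounds shown alone.

The measured compounds:
compound 1 `CCN1CCN(CC(=O)Nc2nc3ccccc3[nH]2)CC1`, which in a functional assay, read by spectrophotometry, with a stated time of 30 min, tested at 5 ug/mL (a higher number here means a stronger effect of the compound at the concentration tested, a lower number a weaker effect), gives 13.3%;
compound 2 `O=C(CN1CCN(c2ccccc2)CC1)Nc1nc2ccccc2[nH]1`, which in this assay gives 4.62%.

Compound 2 is one of only two measured compounds, and its sole companion is compound 1; the step of a number 8.7 percentage points lower from compound 1 to compound 2 (within the scatter) lies within the scatter, so on the numbers shown the two compounds are not told apart.

Compound 3 `O=C(CN1CCN(c2ccccn2)CC1)Nc1nc2ccccc2[nH]1` is the next compound. It differs from compound 2 by pyridin-2-yl in place of phenyl on an amine nitrogen in a ring. Going by the values given here, the one measured step that touches the same ring nitrogen is a number 8.7 percentage points lower from compound 1 to compound 2 (within the scatter), which was within the scatter; that step swapped a different pair of groups, so it bears on the present change only loosely, and no measured step pairs phenyl against pyridin-2-yl. Among the compounds with values here, with that single, small step as the only guide, no shift beyond the scatter is expected from compound 2 to compound 3 in this assay.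

Compound 3 is therefore estimated to give 7% in this assay, with a range from 0% to 20%. That estimate amounts to an expected step of a number 2.4 percentage points higher from compound 2 to compound 3 (within the scatter).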

Compound 3, a percentage reported as activity, at one concentration (the size of the read-out at that concentration, not a potency): 30.8%
Compound 3: the middle estimate sits 23.8 percentage points below what was measured; measured number above the stated range.
By their numbers in this assay, from the lowest: compounds 2 and 1 (each within the scatter of the next); then compound 3.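

At the amine nitrogen in the ring, the group carried there now makes a readable difference in this assay: pyridin-2-yl in place of phenyl gives a number 26.2 percentage points higher from compound 2 to compound 3 (beyond the scatter) and so passes the scatter, as the earlier step at this nitrogen did not. Pyridin-2-yl in place of ethyl gives a number 17.5 percentage points higher from compound 1 to compound 3 (beyond the scatter) and also passes it, which sets compound 3 apart from both compound 1 and compound 2, although those two are not told apart from each other. The change from phenyl keeps the count of heavy atoms and the single six-membered aromatic ring, and it swaps one ring carbon for a nitrogen and adds one hydrogen-bond acceptor, but nothing measured here explains why the number moves.

The compounds shown leave open whether the ring nitrogen must stand where it does in pyridin-2-yl, since neither pyridin-3-yl nor pyridin-4-yl appears among them, and whether pyrimidin-2-yl, with a second ring nitrogen, would carry the number further. With one read-out at one concentration, they also leave open how far the step between these compounds reflects a difference in potency.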